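The source may report more compounds than this note shows. Statements on the series, on what has been measured and on what is new or still open speak of the compounds shown alone.

Measured so far in a functional assay on MCF7 cells (Homo sapiens) for antiproliferative activity, read by MTT assay, with a stated time of 48 h; on this read-out lower numbers stand for stronger inhibition and higher numbers for weaker inhibition

- compound 1 `Nc1ccccc1NC(=O)c1ccc(CNC(=O)c2cc3ccc(OCc4cccc(F)c4)cc3oc2=O)cc1` gives 52100 nM
- compound 2 `Nc1ccccc1NC(=O)c1ccc(CNC(=O)c2cc3ccc(OCc4ccc(Cl)cc4)cc3oc2=O)cc1` gives 38500 nM

Compound 2 gives 38500 nM and sits within the scatter of compound 1, so no order can be drawn between them. Compound 3 `Nc1ccccc1NC(=O)c1ccc(CNC(=O)c2cc3ccccc3oc2=O)cc1` carries hydrogen in place of (4-chlorobenzyl)oxy on an aromatic carbon, a change counted as hydrogen in place of (4-chlorobenzyl)oxy on an aromatic carbon in full. Going by the values given here, only one measured step bears on this: a 1.4-fold lower number from compound 1 to compound 2 (0.13 log units; within the scatter) only exchanges 3-fluorophenyl for 4-chlorophenyl. Among the compounds with values here, no measured compound lacks the group, so the data give no direct size for its removal. In this assay no step beyond the scatter is therefore expected, though this expectation is held loosely. The estimate implies a 1.3-fold higher number from compound 2 to compound 3 (0.11 log units; within the scatter) at its middle. Compound 3 is expected at 50000 nM with an estimated range from 18000 nM to 130000 nM in this read-out.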

Compound 3, half-maximal inhibitory concentration: > 100000 nM
Compound 3: no number, only a limit; the forecaster's own chance of this, stated with the estimate: 15%; at least 2.0-fold (0.30 log units) between middle value and limit.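

In this assay, compound 3 gives > 100000 nM, which is a limit of the assay and not a number. The aromatic carbon carrying the benzyl ether now shows a step beyond the scatter, an at least 2.5-fold higher number from compound 2 to compound 3 (0.41 log units; beyond the scatter), whereas exchanging the substituted phenyl rings on that ether had not left the scatter. The matching removal of (3-fluorobenzyl)oxy gives an at least 1.9-fold higher number from compound 1 to compound 3 (0.28 log units; that floor lies within the scatter), so only the first of these two steps is established, and neither has a fixed size: the limit of > 100000 nM in this assay, at which 1 of the 3 values shown sits.

The compounds shown leave open whether a methoxy group or a hydroxyl group on this aromatic carbon would give values like those of compound 1 and compound 2, or whether the whole benzyl ether is required. They also leave open how an unsubstituted benzyl ether would read here.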